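Cytotoxicity Stays at the Limit Across Four Compounds

The source may report more compounds than this note shows. Statements on the series, on what has been measured and on what is new or still open speak of the compounds shown alone.

The study measured three compounds in an ADME assay on L929 cells (Mus musculus) for cytotoxicity, read by resazurin assay, with a stated time of 72 h; a higher number here means a weaker inhibitor, a lower number a stronger inhibitor. Compound 1 `OB1OCc2ccc(-n3cc(Sc4ccc(F)cc4)c4ccccc43)cc21` gives > 10 ug/mL, which is a limit of the assay rather than a number. Compound 2 `OB1OCc2ccc(-n3cccc3Sc3ccccc3Cl)cc21` gives > 10 ug/mL, again a limit. Compound 3 `O=C(c1ccn(-c2ccc3c(c2)B(O)OC3)c1)c1ccc(Cl)cc1Cl` gives > 10 ug/mL, also a limit. All three values therefore rest at the limit of > 10 ug/mL in this assay, at which 3 of the 3 values shown sit, and compound 3 stands together with the other two rather than apart from them. Compound 4 `Cc1ccsc1C(=O)c1ccn(-c2ccc3c(c2)B(O)OC3)c1` has not yet been measured in this assay. It differs from compound 3 in one place: 3-methylthiophen-2-yl in place of 2,4-dichlorophenyl on a carbonyl carbon. Among the measured compounds shown here, no measured step between any two compounds is available to set the size of such a change. For the measured compounds named here, with every value so far sitting at the limit, the step from compound 3 to compound 4 is expected to be none beyond the scatter in this assay, and the estimated step is a step that the limit leaves unreadable from compound 3 to compound 4. Compound 4 is accordingly expected to give about 15 ug/mL in this assay, within a range from 5 ug/mL to 50 ug/mL, and most likely to be reported once more only as a limit.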

Compound 4, half-maximal inhibitory concentration: > 10 ug/mL
Compound 4 was reported as a limit; the forecaster's own chance of this, stated with the estimate: 80%; the middle value does not contradict the limit.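

Compound 3 and compound 4 are both reported only as limits, so no step can be read between them: the limit of > 10 ug/mL in this assay, at which 4 of the 4 values shown sit.

The compounds shown leave open whether 3-methylthiophen-2-yl in place of 2,4-dichlorophenyl on a carbonyl carbon changes the true cytotoxicity in this assay, and where any of these compounds would give a measurable value.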